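This account rests on a few compounds, and the source may have more. Where it says the series, first, only, none or still open, it means among the compounds named here.

Measured compounds:
Compound 1 `NC1=NC2(CCSCC2)N(OCCCOc2cccc(Cl)c2)C(N)=N1` — 60 nM
Compound 2 `NC1=NC2(CCOCC2)N(OCCCOc2cc(Cl)c(Cl)cc2Cl)C(N)=N1` — 680 nM
Compound 3 `NC1=NC2(CCSCC2)N(OCCCOc2cccc(Cl)c2Cl)C(N)=N1` — 1 nM

In a functional assay on A549 cells (Homo sapiens) for antiproliferative activity, read by MTT assay, with a stated time of 72 h (on this read-out lower numbers stand for stronger inhibition and higher numbers for weaker inhibition), compound 2 gives the highest of the three numbers, with compound 1 nearest and compound 3 furthest away. Compound 4 `NC1=NC2(CCOCC2)N(OCCCOc2ccccc2Cl)C(N)=N1` is not yet measured; it differs from compound 2 by 2-chlorophenyl in place of 2,4,5-trichlorophenyl on an oxygen on a saturated carbon. Among the measured compounds shown here, the one measured step that bears on this is a 60-fold lower number from compound 1 to compound 3 (1.78 log units; beyond the scatter), which shows that a chloro on the aromatic ring of compound 3 goes with a much lower number. Compound 4 keeps a chloro in a position of that kind while losing two others, so a clearly lower number than compound 2 is expected. The estimate for compound 4 is 30 nM (range 5 nM to 200 nM), a step of a 23-fold lower number from compound 2 to compound 4 (1.36 log units; beyond the scatter).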

Compound 4, half-maximal inhibitory concentration: 2700 nM
Compound 4: the middle estimate sits 90-fold (1.95 log units) below what was measured; measured number outside the range, above it.
By their numbers in this assay, from the lowest: compound 3; then compound 1; then compound 2; then compound 4.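

In this assay, the step to the 2-chlorophenyl group is a 4.0-fold higher number from compound 2 to compound 4 (0.60 log units; beyond the scatter), so with this core and at this place on the oxygen chain, losing two chloro groups goes with weaker inhibition. This runs the same way as a 60-fold lower number from compound 1 to compound 3 (1.78 log units; beyond the scatter) and gives a second pair in which more chloro goes with a lower number, here with the chlorines removed rather than added. No measurement available here explains the change.

Which of the two lost chloro groups matters more stays open. So does whether a methoxy or trifluoromethyl group in their place would behave like chloro.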